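From a difluorobenzyl amide back to an aryl amide

The source may report more compounds than this note shows. Statements on the series, on what has been measured and on what is new or still open speak of the compounds shown alone.

Compound 2 `COc1ccc2c(=O)c(/C=C/C(=O)NCc3ccc(F)cc3F)coc2c1` carries a 2,4-difluorobenzyl group on the amide nitrogen of the shared core. In a functional assay on HeLa cells (Homo sapiens) for inhibition, read by MTT assay, with a stated time of 48 h (on this read-out higher numbers stand for weaker inhibition and lower numbers for stronger inhibition), compound 2 gives only a limit, > 100000 nM, not a number. Compound 1 `COc1ccc2c(=O)c(/C=C/C(=O)Nc3cc(C)ccc3C)coc2c1`, with a 2,5-dimethylphenyl group on that nitrogen, gives 58400 nM in this assay. Between them stands one measured step, an at least 1.7-fold higher number from compound 1 to compound 2 (0.23 log units; that floor lies within the scatter), so replacing an aromatic ring attached directly to the nitrogen by a benzyl group moved the number up to the limit (the limit of > 100000 nM in this assay, at which 1 of the 2 values shown sits). Compound 3 `COc1ccc2c(=O)c(/C=C/C(=O)Nc3ccc(C)cc3)coc2c1` reverses that kind of swap: 4-methylphenyl in place of 2,4-difluorobenzyl on an amide-type nitrogen. Within the data shown here, because the only measured step is an at least 1.7-fold higher number from compound 1 to compound 2 (0.23 log units; that floor lies within the scatter), the return to a phenyl-type amide is expected to bring the number down again, roughly by the size seen there, though the limit hides the true size of that step. Compound 3 is therefore estimated at 60000 nM in this assay, within 20000 nM to 150000 nM, which means an expected step of an at least 1.6-fold lower number from compound 2 to compound 3 (0.22 log units; that floor lies within the scatter).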

Compound 3, half-maximal inhibitory concentration: 24100 nM
Beside the measured number, compound 3's estimate is 2.5-fold (0.40 log units) above it; the measured number falls inside the stated range.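

In this assay, putting an aryl group back on the amide-type nitrogen gives an at least 4.1-fold lower number from compound 2 to compound 3 (0.61 log units; beyond the scatter), a step that, unlike the earlier one, clearly exceeds the usual variation between repeated measurements. Compound 2 gives a limit and not a number, so this step is known only as a floor: the limit of > 100000 nM in this assay, at which 1 of the 3 values shown sits. The nitrogen substituent also matters among aryl groups alone, as 4-methylphenyl in place of 2,5-dimethylphenyl gives a 2.4-fold lower number from compound 1 to compound 3 (0.38 log units; beyond the scatter).

The compounds shown do not separate the effect of the direct aryl link to the nitrogen from the effect of swapping fluorine for methyl groups on the ring. A plain benzyl group and an unsubstituted phenyl group on the same nitrogen would help to tell these two apart.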